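The source may hold more compounds than are shown below. What is called first, only, known or untested is meant among the compounds shown, and "the series" means these compounds.

Measured in a functional assay on K562 cells (Homo sapiens) for cytotoxicity, read by MTT assay, with a stated time of 48 h; a higher number here means a weaker inhibitor, a lower number a stronger inhibitor:
- Compound 1 `COc1cc(-n2c(-c3ccc(O)cc3)c[nH]c2=O)cc(OC)c1OC`: > 50000 nM
- Compound 2 `COc1ccc(-c2cn(C(=O)Nc3cc(OC)c(OC)c(OC)c3)c(=O)n2-c2cc(OC)c(OC)c(OC)c2)cc1OC`: > 50000 nM

Compound 2 has no exact number in this assay, only the limit > 50000 nM. The same holds across the set, with the limit of > 50000 nM in this assay, at which 2 of the 2 values shown sit, so neither compound can be ranked against the other.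

Compound 3 `COc1ccc(-c2cn(C(=O)Nc3cc(OC)c(OC)c(OC)c3)c(=O)n2-c2cc(OC)c(OC)c(OC)c2)cc1O` differs from compound 2 in one small way: hydrogen in place of methyl on an oxygen on an aromatic ring. This puts hydrogen in place of methyl on an oxygen on an aromatic ring, changing 3,4-dimethoxyphenyl to 3-hydroxy-4-methoxyphenyl.

For the measured compounds named here, no measured pair shows what this change does. Compound 1 also carries a hydroxy group, and its result is the limit > 50000 nM, so any gain is uncertain. Even so, some measurable gain in strength seems more likely than none. The expected change is an at least 6.2-fold lower number from compound 2 to compound 3 (0.79 log units; beyond the scatter), and this is only an estimate. For compound 3 the estimated value is 8000 nM, with an expected range of 200 nM to 50000 nM.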

Compound 3, half-maximal inhibitory concentration: > 50000 nM
Compound 3 ended at the assay's limit; the forecaster's own chance of this, stated with the estimate: 40%; at least 6.2-fold (0.79 log units) between middle value and limit.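

Compound 3 gives > 50000 nM, which is a limit and not an exact number. No step from compound 2 to compound 3 can be read, because all the results sit at the same limit: the limit of > 50000 nM in this assay, at which 3 of the 3 values shown sit.

The compounds shown leave open whether changing methoxy to hydroxy alters strength at all.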